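The source may report more compounds than this note shows. Statements on the series, on what has been measured and on what is new or still open speak of the compounds shown alone.

Three compounds were measured in a functional assay on DU-145 cells (Homo sapiens) for inhibition, read by sulforhodamine B assay, with a stated time of 48 h, tested at 10 uM; a lower number here means less inhibition, a higher number more inhibition at the concentration tested (going by the name of the read-out):

Compound 1 `c1ccc(-c2cn3ccnc3c(-c3ccc4ncn(C5CCCCC5)c4c3)n2)cc1`: 29.3%
Compound 2 `COc1ccc(-c2cn3ccnc3c(-c3ccc4ncn(C5CCCCC5)c4c3)n2)cc1`: 81.8%
Compound 3 `c1cn2cc(-c3ccsc3)nc(-c3ccc4ncn(C5CCCCC5)c4c3)c2n1`: 1.36%

Compound 2 stands highest of the three in this assay, beyond the scatter from both others. Compound 4 `Fc1ccccc1-c1cn2ccnc2c(-c2ccc3ncn(C4CCCCC4)c3c2)n1` differs from compound 2 in one place: 2-fluorophenyl in place of 4-methoxyphenyl on an aromatic carbon. The step that bears most on this is a number 52.5 percentage points higher from compound 1 to compound 2 (beyond the scatter), where adding the methoxy group to a plain phenyl gave a large gain; compound 4 gives that group up and carries a fluorine instead. The step of a number 80.4 percentage points lower from compound 2 to compound 3 (beyond the scatter) also shows a large loss when the 4-methoxyphenyl is replaced. A large drop is therefore expected, a number 51.8 percentage points lower from compound 2 to compound 4 (beyond the scatter), leaving compound 4 near compound 1. Compound 4 is estimated at 30%, in a range from 5% to 60%.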

Compound 4, a percentage reported as inhibition, at one concentration (the size of the read-out at that concentration, not a potency): 0.96%
Compound 4: the middle estimate sits 29 percentage points above what was measured; the measured number lies below the stated range.
By their numbers in this assay, from the lowest: compounds 4 and 3 (each within the scatter of the next); then compound 1; then compound 2.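

In this assay, 2-fluorophenyl does not keep the gain seen with 4-methoxyphenyl, with a number 80.8 percentage points lower from compound 2 to compound 4 (beyond the scatter), and a substituent on the phenyl ring can also lower the number, with a number 28.3 percentage points lower from compound 1 to compound 4 (beyond the scatter). Against the thiophen-3-yl group the 2-fluorophenyl group shows a number 0.4 percentage points lower from compound 3 to compound 4 (within the scatter), so these two groups cannot be told apart here. No measurement available here explains these differences. The compounds shown leave open whether the loss comes from the fluorine itself or from where it sits on the ring, and how an ethoxy group or an amine in place of the methoxy would read.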